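Trimming a Methoxy from the Aryl Ketone of Compound 3

A few compounds are considered here, and "the series" means these few. Any claim that something is new, unique, unknown or untested is made for them only; others in the source may bear on it.

Compound 3 `COc1ccc(-c2cc(/C=C/C(=O)c3ccc(OC)c(OC)c3)nc3cc(-c4ccccc4)nn23)cc1` holds the second highest of the three numbers in a functional assay on A549 cells (Homo sapiens) for antiproliferative activity, read by MTT assay, with a stated time of 24 h (a lower number here means a stronger inhibitor, a higher number a weaker inhibitor), giving 7400 nM. Compound 1 `COc1ccc(C(=O)/C=C/c2cc(-c3cc(OC)c(OC)c(OC)c3)n3nc(-c4ccccc4)cc3n2)cc1OC` gives 17800 nM in this assay, while compound 2 `COc1ccc(C(=O)/C=C/c2cc(-c3ccc(OC)c(OC)c3)n3nc(-c4ccccc4)cc3n2)cc1OC` gives 3900 nM. Compound 4 `COc1ccc(C(=O)/C=C/c2cc(-c3ccc(OC)cc3)n3nc(-c4ccccc4)cc3n2)cc1` differs from compound 3 by hydrogen in place of methoxy on an aromatic carbon. Two measured steps involve the same kind of change: a 4.6-fold lower number from compound 1 to compound 2 (0.66 log units; beyond the scatter), and a 1.9-fold higher number from compound 2 to compound 3 (0.28 log units; within the scatter). Both of those steps, however, removed methoxy from the aryl group attached to the shared core rather than from the (3,4-dimethoxyphenyl)carbonyl, and they point in opposite directions, so no step beyond the scatter is expected here. Compound 4 is therefore estimated at 7000 nM, with a range from 2500 nM to 20000 nM. This estimate corresponds to an expected step of a 1.1-fold lower number from compound 3 to compound 4 (0.02 log units; within the scatter).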

Compound 4, half-maximal inhibitory concentration: 2900 nM
The estimate for compound 4 lay 2.4-fold (0.38 log units) above the measured number; the range from low to high includes it.
By their numbers in this assay, from the lowest: compounds 4, 2 and 3 (each within the scatter of the next, the first and the last beyond it); then compound 1.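

In this assay, the step to (4-methoxyphenyl)carbonyl gives a 2.6-fold lower number from compound 3 to compound 4 (0.41 log units; beyond the scatter), the first change shown on this aryl ketone, and it shows that this methoxy position does register in the read-out. The step from compound 2 to compound 3 goes against any general rule, staying within the scatter, but the same exchange of methoxy for hydrogen lowers the number by a similar amount on two cores: the same change on two cores in this assay, a 4.6-fold lower number (0.66 log units; beyond the scatter) from compound 1 to compound 2 and a 2.6-fold lower number (0.41 log units; beyond the scatter) from compound 3 to compound 4, 1.8-fold (0.25 log units) apart, within the scatter of two such steps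

The compounds shown leave open how a hydroxy group, a fluorine atom or an amine would compare with hydrogen at this position. They also leave open what happens if the remaining methoxy on this ring is replaced.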